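Stereochemical inversion at two ring carbons, number expected lower or level

The source may hold more compounds than are shown below. What is called first, only, known or untested is meant among the compounds shown, and "the series" means these compounds.

Working notes on a small hydroxylated series tested in an assay on isolated protein for inhibition of cytosolic endo-beta-N-acetylglucosaminidase (Homo sapiens), tested at 1000 uM; on this read-out lower numbers stand for less inhibition and higher numbers for more inhibition at the one concentration tested (going by the name of the read-out). Compound 1 `O=C(O)[C@@H]1NC[C@@H](O)[C@@H](O)[C@H]1O` gives 26% in this assay. Compound 2 `O=C(O)[C@H]1NCC=C[C@H]1O` gives 17% in this assay, and the gap to compound 1 lies within the usual scatter, so the two measured compounds are not separated from one another; both sit at low inhibition at the single concentration tested.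

The next compound, compound 3 `O=C(O)[C@@H]1NC[C@@H](O)[C@H](O)[C@@H]1O`, differs from compound 1 as follows: the two compounds have the same atoms and bonds and differ only in configuration as drawn: 2 of 4 stereo elements differ; a stereocentre at a saturated ring carbon is drawn R in compound 1 and S in compound 3; a stereocentre at a saturated ring carbon is drawn S in compound 1 and R in compound 3. Among the measured compounds shown here, no step between measured compounds is available to calibrate what a change of configuration alone does here. With both measured numbers low and close together, the step from compound 1 to compound 3 is expected to be small, a number 6 percentage points lower from compound 1 to compound 3 (within the scatter), within or just beyond the scatter, with a slight lean downward. Compound 3 is therefore estimated at 20% in this assay, with a plausible range from 5% to 45%.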

Compound 3, a percentage reported as inhibition, at one concentration (the size of the read-out at that concentration, not a potency): 0.8%
The estimate for compound 3 lay 19.2 percentage points above the measured number; the whole stated range lies above it.
By their numbers in this assay, from the lowest: compound 3; then compounds 2 and 1 (each within the scatter of the next).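

In this assay, among the compounds shown here, the change of two of the four stereo elements, both at saturated ring carbons, gives a number 25.2 percentage points lower from compound 1 to compound 3 (beyond the scatter), the first step to separate two compounds. For the compounds shown here, the earlier numbers could not show this, as no configuration-only pair was available, and the new pair shows that the arrangement of the hydroxyl groups matters at this level of inhibition, even though the atoms and bonds stay the same. The step can be assigned to configuration alone because nothing else changes within the pair: the fact that compounds 1 and 3 differ only in the configuration as drawn

The compounds shown do not separate the two inverted carbons, so it remains open whether one of them alone carries the step or both are needed. Also open, on these data alone, is how a methyl ester in place of the carboxylic acid would read out on either configuration.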